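Amide aryl swap on the shared sulfonamide core

The compounds below may be only part of what the source reports. "The series", "measured", "known", "first", "only" and "open" are said of these compounds alone.

Compound 1 `Cc1ccc(S(=O)(=O)NCc2ccc(CNC(=O)c3ccncc3)cc2)cc1` gives 10 nM in an assay on MDA-MB-231 cells for binding affinity to C-X-C chemokine receptor type 4 (Homo sapiens), read by immunofluorescence and microscopy, with stated times of 10 min and 30 min; a higher number here means that more compound is needed for the effect, a lower number that less compound is needed. Compound 2 `O=C(NCc1ccc(CNS(=O)(=O)c2ccccc2)cc1)c1ccccc1Cl` gives 10 nM in this assay, so compound 1 is level with compound 2 at the digits shown, and together they hold the highest numbers of the three measured. Compound 3 `COc1ccccc1C(=O)NCc1ccc(CNS(=O)(=O)c2ccccc2)cc1` gives 1 nM in this assay, a lower number than compound 1, beyond the scatter. Within the data shown here, the one single-point step among the measured compounds is a 10-fold lower number from compound 2 to compound 3 (1.00 log units; beyond the scatter), the only hint so far that a methoxy group on the amide-side aryl goes with lower numbers.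

Compound 4 `COc1cccc(C(=O)NCc2ccc(CNS(=O)(=O)c3ccc(C)cc3)cc2)c1` differs from compound 1 by 3-methoxyphenyl in place of pyridin-4-yl on a carbonyl carbon. Among the measured compounds shown here, no measured step covers this exchange of a pyridin-4-yl for a 3-methoxyphenyl; the step from compound 2 to compound 3 bears on it only loosely, since there the methoxy replaces chloro rather than a ring nitrogen and sits on a different carbon of the aryl. Given that loose parallel, a modest lowering in this assay or none beyond the scatter is expected, and an upward step is not expected. Compound 4 is therefore estimated at 5 nM, with a range from 1.5 nM to 20 nM, which would mean an expected step of a 2.0-fold lower number from compound 1 to compound 4 (0.30 log units; within the scatter).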

Compound 4, effective concentration (reported as EC, without a stated level of effect): 10 nM
For compound 4 the middle estimate is 2.0-fold (0.30 log units) below the measured one; the measured number falls inside the stated range.
By their numbers in this assay, from the lowest: compound 3; then compounds 1, 2 and 4 (each within the scatter of the next).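

The exchange of pyridin-4-yl for 3-methoxyphenyl on the carbonyl carbon gives no change at the digits printed from compound 1 to compound 4 (within the scatter) in this assay, so with the rest of compound 1 held fixed, the ring nitrogen of the pyridin-4-yl is not needed to keep the number at this level, and a carbon-only aromatic ring carrying a methoxy is accepted here. Among these compounds, compound 4 also goes against the earlier hint: it carries a methoxy on the amide-side aryl, yet the only step to a lower number remains a 10-fold lower number from compound 2 to compound 3 (1.00 log units; beyond the scatter), and that step replaces chloro rather than a pyridine ring. No evidence at hand explains why this exchange leaves the number in place.

Compound 3 and compound 4 differ in more than one place, so the series does not separate the placement of the methoxy from the methyl on the sulfonyl-side aryl. As far as these compounds go, it also remains open how this position responds to a dimethylamino group, a carboxylic acid or a longer chain in place of the aryl ring.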